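The source may hold more compounds than are shown below. What is called first, only, known or untested is meant among the compounds shown, and "the series" means these compounds.

The shared core appears in compound 1 `Cc1ccc2cc(CNCc3ccc(F)cc3)c(=O)[nH]c2c1`, compound 2 `Cc1ccc2[nH]c(=O)c(CN(Cc3ccc(F)cc3)Cc3cccc4ccccc34)cc2c1` and compound 3 `Cc1ccc2[nH]c(=O)c(CN(Cc3ccc(OCC(=O)OC(C)(C)C)cc3)Cc3ccc(C(C)(C)C)cc3)cc2c1`. In a toxicity assay on MDCK cells (Canis lupus familiaris) for cytotoxicity, read by crystal violet staining, with a stated time of 48 h (a higher number here means that more compound is tolerated, a lower number that less compound is tolerated), compound 1 reaches only a limit of the assay, > 33000 nM. Compound 2 likewise gives only a limit in this assay, > 5000 nM. Compound 3 also stops at a limit in this assay, > 10000 nM. Compound 3 thus stands at the limit of > 10000 nM in this assay, at which 1 of the 3 values shown sits, so none of the values shown is a number. Compound 4 `Cc1ccc2[nH]c(=O)c(CN(Cc3ccc(SC(F)F)cc3)Cc3ccc(C(C)(C)C)cc3)cc2c1` differs from compound 3 by (difluoromethyl)sulfanyl in place of (tert-butoxycarbonyl)methoxy on an aromatic carbon. For the measured compounds named here, with no measured step between these compounds to lean on, no shift beyond the scatter is expected in this assay. Compound 4 is therefore estimated at 20000 nM, between 5000 nM and 100000 nM. The step this estimate implies, a step that the limit leaves unreadable from compound 3 to compound 4, is expected to stay within the scatter.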

Compound 4, half-maximal cytotoxic concentration: > 5000 nM
Compound 4 gave a limit, no number; the forecaster's own chance of this, stated with the estimate: 80%; the middle value lies beyond the limit too.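

For the compounds shown here, compound 3 and compound 4 both stop at limits in this assay, so no step between them can be read. The compounds shown leave open what half-maximal cytotoxic concentration any of them has, and whether (difluoromethyl)sulfanyl in place of (tert-butoxycarbonyl)methoxy shifts it.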